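The source may report more compounds than this note shows. Statements on the series, on what has been measured and on what is new or still open speak of the compounds shown alone.

Of the compounds shown here, three built on one shared core have been measured in a functional assay on HEK293 cells for agonist activity at D(4) dopamine receptor (Homo sapiens), read by FLIPR; a higher number here means a larger maximal response, a lower number a smaller maximal response. Compound 1 `O=C(CN1CCC(c2cccc[n+]2[O-])CC1)Nc1cc(Cl)cc(Cl)c1` gives 68%, compound 2 `O=C(CN1CCC(c2cccc[n+]2[O-])CC1)Nc1ccc(F)cc1` gives 71%, and compound 3 `O=C(CN1CCC(c2cccc[n+]2[O-])CC1)Nc1cccc(-c2ccccc2)c1` gives 75%, so compound 3 sits at the upper end of the three numbers while staying within the scatter of both others. Compound 4 `O=C(CN1CCC(c2cccc[n+]2[O-])CC1)Nc1cccc(OC(F)(F)F)c1` has not yet been measured; it differs from compound 3 in one place: trifluoromethoxy in place of phenyl on an aromatic carbon. Among the compounds with values here, the only measured step that also alters the ring on the amide-type nitrogen, a number 3 percentage points higher from compound 1 to compound 2 (within the scatter), stays within the scatter, so no step beyond the scatter is expected in this assay. Compound 4 is therefore expected to give 70%, between 55% and 85%. The expected step is a number 5 percentage points lower from compound 3 to compound 4 (within the scatter).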

Compound 4, largest response reached (reported as efficacy), in percent of the reference or control that the assay uses: 51%
Compound 4: the middle estimate sits 19 percentage points above what was measured; measured number below the stated range.
By their numbers in this assay, from the lowest: compound 4; then compounds 1, 2 and 3 (each within the scatter of the next).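

In this assay, trifluoromethoxy in place of phenyl gives a number 24 percentage points lower from compound 3 to compound 4 (beyond the scatter), the first step shown here that lies beyond the scatter. The maximal response therefore depends on what sits on this aromatic carbon, meta to a large group, which the step between compound 1 and compound 2 did not reveal. Nothing available explains this drop.

On these data alone, whether a methoxy group, a chlorine atom or an amine on this carbon would stay near compound 3 or fall towards compound 4 remains open.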